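The source may hold more compounds than are shown below. What is called first, only, known or untested is meant among the compounds shown, and "the series" means these compounds.

Compound 1 `C/C(=C\CC/C(C)=C/CC[C@@H]1[C@@]2(C)CCC(=O)C(C)(C)[C@H]2CC[C@@]1(C)O)CC/C=C(\C)C(=O)OCc1cn(-c2ccccc2Cl)nn1`: > 150000 nM
Compound 2 `C/C(=C\CC/C(C)=C/CC[C@@H]1[C@@]2(C)CCC(=O)C(C)(C)[C@H]2CC[C@@]1(C)O)CC/C=C(\C)C(=O)OCc1cn(-c2cccc(O)c2)nn1`: 28400 nM
Compound 3 `C/C(=C\CC/C(C)=C/CC[C@@H]1[C@@]2(C)CCC(=O)C(C)(C)[C@H]2CC[C@@]1(C)O)CC/C=C(\C)C(=O)OCc1cn(-c2ccccc2)nn1`: 95500 nM

The three measured compounds share one core and differ only in the aryl group carried on an aromatic nitrogen. In a functional assay on DU-145 cells (Homo sapiens) for antiproliferative activity, read by MTT assay, with a stated time of 48 h (on this read-out higher numbers stand for weaker inhibition and lower numbers for stronger inhibition), compound 1 reaches only the limit (the limit of > 150000 nM in this assay, at which 1 of the 3 values shown sits), not a number. Among the two numbers, compound 3 stands highest, its nearest neighbour being compound 2, from which the removal of the hydroxy group gives a 3.4-fold higher number from compound 2 to compound 3 (0.53 log units; beyond the scatter), a modest step beyond the scatter. The step of an at least 1.5-fold lower number from compound 1 to compound 3 (0.19 log units; that floor lies within the scatter) has a floor that lies within the scatter, while an at least 5.2-fold lower number from compound 1 to compound 2 (0.72 log units; beyond the scatter) is at least modest.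

Compound 4 `C/C(=C\CC/C(C)=C/CC[C@@H]1[C@@]2(C)CCC(=O)C(C)(C)[C@H]2CC[C@@]1(C)O)CC/C=C(\C)C(=O)OCc1cn(-c2ccc([N+](=O)[O-])cc2)nn1` differs from compound 3 by nitro in place of hydrogen on an aromatic carbon. Among the compounds with values here, no measured step adds a nitro group, and the two steps that bear on substitution of this aryl group point in different directions, so the writer expects in this assay only a step of about a 1.4-fold lower number from compound 3 to compound 4 (0.13 log units; within the scatter), near the edge of the scatter. For compound 4 he estimates 70000 nM, within a range of 20000 nM to 150000 nM.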

Compound 4, half-maximal inhibitory concentration: > 150000 nM
Compound 4: no number, only a limit; the forecaster's own chance of this, stated with the estimate: 25%; middle value at least 2.1-fold (0.33 log units) away from the limit.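

In this assay compound 4 gives no number, only a limit, and it is the second compound shown to end there: the limit of > 150000 nM in this assay, at which 2 of the 4 values shown sit.

Nitro on this phenyl ring, para to a large group, thus brings no gain over the plain phenyl of compound 3, with an at least 1.5-fold higher number from compound 3 to compound 4 (0.19 log units; that floor lies within the scatter), while the 4-nitrophenyl group falls clearly behind the 3-hydroxyphenyl group, with an at least 5.2-fold higher number from compound 2 to compound 4 (0.72 log units; beyond the scatter), so that compound 2 remains the only one of the substituted compounds shown to give a number, with compound 1 and compound 4 going the other way. The step between compound 1 and compound 4 cannot be read, as both values are limits.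

Going by these compounds, how an amine or a carboxylic acid on this phenyl ring would read in this assay stays open. On these data alone, it is also open whether nitro on another carbon of the ring would leave the same result.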